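The source may report more compounds than this note shows. Statements on the series, on what has been measured and on what is new or still open speak of the compounds shown alone.

Compound 1 `Cc1oc2c3c(ccc2c(=O)c1C)OC[C@H]1[C@@H]3c2c(ccc(C(=O)Cc3ccccc3)c2O)OC1(C)C` in a functional assay on MDA-MB-231 cells (Homo sapiens) for cytotoxicity, read by MTT assay (a higher number here means a weaker inhibitor, a lower number a stronger inhibitor), gives only the assay's limit, > 100000 nM.
Compound 2 `Cc1coc2c3c(ccc2c1=O)OC[C@H]1[C@@H]3c2c(ccc(C(=O)Cc3ccccc3)c2O)OC1(C)C` in this assay likewise gives only the limit, > 100000 nM.
Compound 3 `Cc1oc2c3c(ccc2c(=O)c1C)OC[C@H]1[C@@H]3c2ccc3ccccc3c2OC1(C)C` in this assay also gives only the limit, > 100000 nM.

Compound 3 therefore stands at the limit of this assay, together with the two other measured compounds; none of the three has a numerical reading, and nothing among them can be ranked.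

Compound 4 is `Cc1coc2c3c(ccc2c1=O)OC[C@H]1[C@@H]3c2ccc3ccccc3c2OC1(C)C`. It differs from compound 3 by hydrogen in place of methyl on an aromatic carbon. The same exchange has been made once before, from compound 1 to compound 2, where the step was a step that the two limits leave unreadable from compound 1 to compound 2. That step bears directly on the change in hand, but its size is not readable because the limit of > 100000 nM in this assay, at which 3 of the 3 values shown sit: both ends of it, and compound 3 as well, sit at the same limit. So there is no measured step with a known size from which to draw, and no direction can be expected beyond the scatter; the only expectation the data support is that compound 4 will most likely again return the limit rather than a number.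

On that basis the step from compound 3 to compound 4 is expected to be a step that the limit leaves unreadable from compound 3 to compound 4. For compound 4 the estimate in this assay is 150000 nM, with a range from 40000 nM to 600000 nM.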

Compound 4, half-maximal inhibitory concentration: > 100000 nM
Compound 4 ended at the assay's limit (the forecaster's own chance of this, stated with the estimate: 80%); the middle value lies beyond the limit too.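

Compound 4 returns the same limit as compound 3, so no size can be read for the step between them, which puts hydrogen in place of methyl on an aromatic carbon: the limit of > 100000 nM in this assay, at which 4 of the 4 values shown sit.

The compounds shown leave open whether this exchange alters the reading in this assay at all, and whether any compound sharing this core would give a numerical value.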